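Swapping hydroxymethyl for methoxy on compound 3

The compounds below may be only part of what the source reports. "The series", "measured", "known", "first", "only" and "open" are said of these compounds alone.

Measured in a functional assay on PANC-1 cells (Homo sapiens) for cytotoxicity, read by MTT assay, with a stated time of 72 h; on this read-out lower numbers stand for stronger inhibition and higher numbers for weaker inhibition:
- compound 1 `Nc1ccc(-c2ccc(NC3=CC(=O)c4ncncc4C3=O)cc2)cc1`: 3700 nM
- compound 2 `COc1ccc(-c2ccc(NC3=CC(=O)c4ncncc4C3=O)cc2)cc1`: 2300 nM
- compound 3 `O=C1C(Nc2ccc(CO)cc2)=CC(=O)c2ncncc21`: 1000 nM

Compound 3 has the lowest number of the three, and both gaps to it lie beyond the scatter: a 3.7-fold lower number from compound 1 to compound 3 (0.57 log units; beyond the scatter), and a 2.3-fold lower number from compound 2 to compound 3 (0.36 log units; beyond the scatter). The next compound to consider is compound 4 `COc1ccc(NC2=CC(=O)c3ncncc3C2=O)cc1`. It changes one group of compound 3: methoxy in place of hydroxymethyl on an aromatic carbon. Methoxy stands in place of hydroxymethyl on an aromatic carbon, para to a large group.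

Going by the values given here, no measured step makes exactly this swap, so two steps serve as loose guides. In the first, methoxy replaces amino, and a 1.6-fold lower number from compound 1 to compound 2 (0.21 log units; within the scatter) stays within the scatter. The second, a 2.3-fold lower number from compound 2 to compound 3 (0.36 log units; beyond the scatter), suggests that the methoxy side may carry the higher number. However, that step replaces a whole 4-methoxyphenyl, not just a methoxy, so it deserves limited weight. A modest rise is therefore expected, and it may not clear the scatter. The expected step is a 1.6-fold higher number from compound 3 to compound 4 (0.20 log units; within the scatter). The estimated value for compound 4 is 1600 nM, with an expected range of 600 nM to 4000 nM.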

Compound 4, half-maximal inhibitory concentration: 800 nM
Beside the measured number, compound 4's estimate is 2.0-fold (0.30 log units) above it, within the range that was stated.
By their numbers in this assay, from the lowest: compounds 4 and 3 (each within the scatter of the next); then compounds 2 and 1 (each within the scatter of the next).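

In this assay, the swap of hydroxymethyl for methoxy gives a 1.3-fold lower number from compound 3 to compound 4 (0.10 log units; within the scatter) and so shows no readable difference, even though the hydrogen-bond donor of hydroxymethyl is gone and methoxy has none. Going by these compounds alone, this is the first direct view of two small groups of the same heavy-atom count at this position, and here the donor count alone does not separate them. Compound 4 also sits clearly apart from the two compounds with a larger group in this place, as a 2.9-fold lower number from compound 2 to compound 4 (0.46 log units; beyond the scatter) and a 4.6-fold lower number from compound 1 to compound 4 (0.67 log units; beyond the scatter) both show, which matches the earlier gaps for compound 3 and strengthens the link between the two small groups and lower numbers among these four compounds. Nothing available explains either the missing difference or these larger gaps.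

The compounds shown leave open whether the same holds for other small groups at this position, such as an amine, a carboxylic acid or a longer chain like ethoxy. They also leave open how methoxy or hydroxymethyl would fare at another place on this ring, since every group here sits para to a large group.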